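The source may hold more compounds than are shown below. What is called first, only, known or untested is meant among the compounds shown, and "the series" means these compounds.

Of the compounds shown here, two with the same core have been tested in an assay for inhibition of Polyunsaturated fatty acid 5-lipoxygenase (Homo sapiens), read by spectrophotometry, tested at 20 uM; on this read-out lower numbers stand for less inhibition and higher numbers for more inhibition at the one concentration tested (going by the name of the read-out). Compound 1 `O=C(/C=C/C=C/c1ccc(F)cc1)N1CCCCC1` gives 48.7%. Compound 2 `O=C(/C=C/C=C/c1ccc(O)cc1)N1CCCCC1`, which carries a hydroxy in place of the fluoro on the aromatic carbon, gives 44.4% in this assay. Among the measured compounds shown here, the move between them, a number 4.3 percentage points lower from compound 1 to compound 2 (within the scatter), does not rise above the scatter of the measurement, so compound 2 stands alongside compound 1 rather than apart from it; it is the nearest and only neighbour it has among the numbers so far.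

Compound 3 `CC(=O)Oc1ccc(/C=C/C=C/C(=O)N2CCCCC2)cc1` is not yet measured. Compared with compound 2 the change is acetyl in place of hydrogen on an oxygen on an aromatic ring. For the measured compounds named here, no measured step concerns an acetyl group. Going by the values given here, the only step available, from fluoro to hydroxy at the same aromatic carbon, stayed within the scatter, which gives no reason to expect that a further change at that hydroxy will shift this assay far. The expected step is therefore a number 0.4 percentage points lower from compound 2 to compound 3 (within the scatter), none beyond the scatter. Compound 3 is thus estimated to give 44%, with a range from 24% to 64%.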

Compound 3, a percentage reported as inhibition, at one concentration (the size of the read-out at that concentration, not a potency): 18.3%
Estimate against measurement, compound 3: 25.7 percentage points above, outside the stated range (below it).
By their numbers in this assay, from the lowest: compound 3; then compounds 2 and 1 (each within the scatter of the next).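

The aromatic carbon that carries the substituent is not as indifferent in this assay as the first pair suggested: fluoro and hydroxy sit within the scatter of each other, but placing an acetyl on the oxygen on the aromatic ring gives a number 26.1 percentage points lower from compound 2 to compound 3 (beyond the scatter) and so brings a clear loss of inhibition at the one concentration tested. Set against the fluoro compound, the same position gives a number 30.4 percentage points lower from compound 1 to compound 3 (beyond the scatter), so the two routes to the acetoxy group agree, and on these three compounds the read-out responds to this group rather than to every change at this carbon. Nothing available here accounts for the drop, so the data show that it happens but not what lies behind it.

The compounds shown leave open whether the loss follows from covering the oxygen at all or from the acetyl group in particular, which a methoxy on the same aromatic carbon would help to separate. They also leave open how an amine at this carbon, or a longer acyl chain such as propanoyl on the oxygen, would compare with the hydroxy and acetoxy groups.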